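Positional isopropyl shift on the aryl ether of compound 2

The source may hold more compounds than are shown below. What is called first, only, known or untested is meant among the compounds shown, and "the series" means these compounds.

Among the compounds with values here, compound 1 `CO[C@H]1O[C@H](COc2cccc(C(C)C)c2)[C@@H](O)[C@H](O)[C@H]1Oc1ccc(OC2CCCCC2)cc1` and compound 2 `CO[C@H]1O[C@H](COc2ccc(-c3ccccc3)cc2)[C@@H](O)[C@H](O)[C@H]1Oc1ccccc1C(C)C` are the two measured members of this set; compound 3 `CO[C@@H]1O[C@H](COc2ccc(-c3ccccc3)cc2)[C@@H](O)[C@H](O)[C@H]1Oc1ccccc1` carries no reported number, as in a functional assay on MDA-MB-231 cells (Homo sapiens) for cytotoxicity, read by MTT assay, with a stated time of 48 h (on this read-out lower numbers stand for an effect already at smaller amounts and higher numbers for an effect only at larger amounts of compound), compound 3 gives "not determined" (no result reported). In this assay compound 2 gives 34000 nM, and compound 1 gives 38000 nM, the two lying within the scatter of each other, so compound 2 holds the lowest of two numbers without any order between them. Compound 4 `CO[C@H]1O[C@H](COc2ccc(-c3ccccc3)cc2)[C@@H](O)[C@H](O)[C@H]1Oc1cccc(C(C)C)c1` differs from compound 2 only in the aryl group on the oxygen on a saturated carbon: 3-isopropylphenyl in place of 2-isopropylphenyl on an oxygen on a saturated carbon. Within the data shown here, with no step between measured compounds to lean on, the change is expected to move the number by no more than the scatter, in no preferred direction, giving an estimated 1.0-fold higher number from compound 2 to compound 4 (0.01 log units; within the scatter). Compound 4 is therefore expected at 35000 nM, with a range from 15000 nM to 80000 nM.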

Compound 4, half-maximal effective concentration: 30000 nM
Estimate against measurement, compound 4: 1.2-fold (0.07 log units) above; measured number inside the range.
By their numbers in this assay, from the lowest: compounds 4, 2 and 1 (each within the scatter of the next).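

Within the data shown here, exchanging 2-isopropylphenyl for 3-isopropylphenyl on the oxygen on a saturated carbon gives the first step between matched compounds: in this assay it is a 1.1-fold lower number from compound 2 to compound 4 (0.05 log units; within the scatter) and stays within the scatter. On this read-out, the two isomers cannot be told apart at this place. Nothing available bears on why this is so.

Still open, going by these compounds, is whether 4-isopropylphenyl, or a phenyl carrying an amine or a carboxylic acid, would move the number at this place. Whether any change here can lead to a clearly lower number also remains unresolved.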